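Dropping a Methyl From the Anilide Ring of Compound 1

The compounds below may be only part of what the source reports. "The series", "measured", "known", "first", "only" and "open" are said of these compounds alone.

The measured compounds:
Compound 1, `Cc1cc(NC(=O)CN2CCC(c3cccc[n+]3[O-])CC2)ccc1F`, gives 75% in a functional assay on HEK293 cells for agonist activity at D(4) dopamine receptor (Homo sapiens), read by FLIPR; on this read-out higher numbers stand for larger maximal responses and lower numbers for smaller maximal responses.
Compound 2, `Cc1cccc(NC(=O)CN2CCC(c3cccc(O)c3)CC2)c1`, gives 66%.
Compound 3, `C=Cc1cccc(C(=O)NCN2CCC(c3cccc[n+]3[O-])CC2)c1`, gives 63%.

Compound 1 shows the highest number of the three, but only with a caveat: compound 2 lies within the usual scatter of it, so no order between these two can be claimed, and only compound 3 sits beyond the scatter below compound 1. No two of the measured compounds differ in a single place, so the numbers themselves are all that can be said of them.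

Compound 4, `O=C(CN1CCC(c2cccc[n+]2[O-])CC1)Nc1ccc(F)cc1`, is the unmeasured analogue of compound 1. It differs from compound 1 in one place: hydrogen in place of methyl on an aromatic carbon. The shared core and the amide linker are untouched.

Among the measured compounds shown here, with no single-change step among the measured compounds to lean on, a small step is expected in this assay, most likely none beyond the scatter, since the change removes a single carbon on the outer aromatic ring; the expected step is a number 5 percentage points lower from compound 1 to compound 4 (within the scatter). Compound 4 is therefore estimated at 70%, within a range from 55% to 85%.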

Compound 4, largest response reached (reported as efficacy), in percent of the reference or control that the assay uses: 71%
Compound 4: middle estimate off by 1 percentage points, on the low side; measured number inside the range.
By their numbers in this assay, from the lowest: compounds 3, 2, 4 and 1 (each within the scatter of the next, the first and the last beyond it).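

In this assay, the series now has its first single-change step, a number 4 percentage points lower from compound 1 to compound 4 (within the scatter), and it shows that hydrogen can stand in place of methyl on this aromatic carbon, ortho to the fluoro group, with the maximal response staying within the scatter. Among the compounds shown here, the 4-fluorophenyl group of compound 4 thus serves as well as the 4-fluoro-3-methylphenyl group of compound 1 on this read-out, something the earlier compounds, none of which differed in a single place, could not show. Nothing available bears on why the step is this small.

On these data alone, what an ethyl, a methoxy or an amine at the same carbon would give remains open. So does whether the methyl-to-hydrogen step would stay this small with the fluoro group replaced by chlorine or hydrogen.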